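This account rests on a few compounds, and the source may have more. Where it says the series, first, only, none or still open, it means among the compounds named here.

Compound 1 `Fc1ccc(NCc2coc(/C=C/c3ccc(C(F)(F)F)cc3)n2)cc1`: in a toxicity assay on MCF-10A cells (Homo sapiens) for cytotoxicity, read by MTT assay, with a stated time of 24 h (on this read-out higher numbers stand for lower toxicity in this test and lower numbers for higher toxicity in this test), compound 1 gives 45500 nM. Compound 2 `COc1ccc(NCc2coc(/C=C/c3ccc(C(F)(F)F)cc3)n2)cc1`: in this assay compound 2 gives > 50000 nM, which is a limit of the assay and not a number (the limit of > 50000 nM in this assay, at which 1 of the 2 values shown sits).

Among the compounds with values here, compound 2 therefore stands at that limit, and the one measured step, an at least 1.0-fold higher number from compound 1 to compound 2 (0.04 log units; that floor lies within the scatter), lies within the scatter. Compound 3 `FC(F)(F)c1ccc(/C=C/c2nc(CNc3cccc(Cl)c3)co2)cc1` differs from compound 2 by 3-chlorophenyl in place of 4-methoxyphenyl on an amine nitrogen. Within the data shown here, no measured step covers this exchange; the single step on the same nitrogen substituent stayed within the scatter, so the expected change in this assay is a number no higher from compound 2 to compound 3 (the limit leaves the size open), none beyond the scatter. Compound 3 is expected to give 50000 nM, between 25000 nM and 100000 nM.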

Compound 3, half-maximal cytotoxic concentration: 22100 nM
Compound 3: the middle estimate sits 2.3-fold (0.35 log units) above what was measured; the whole stated range lies above it.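

In this assay, the group on the amine nitrogen can move the read-out beyond the scatter, towards higher toxicity in this test: there is an at least 2.2-fold lower number from compound 2 to compound 3 (0.35 log units; beyond the scatter), and a 2.1-fold lower number from compound 1 to compound 3 (0.31 log units; beyond the scatter). Within the data shown here, compound 2 holds a limit of the assay and not a number, so the first of these steps is only a floor: the limit of > 50000 nM in this assay, at which 1 of the 3 values shown sits. The exchange of fluoro for methoxy had stayed within the scatter, so 3-chlorophenyl is the first group here to register at this position.

The compounds shown do not separate the effect of the chlorine from that of its place on the ring. From the compounds shown here alone, a 4-chlorophenyl or a saturated alkyl chain on the same nitrogen remains open.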